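This account rests on a few compounds, and the source may have more. Where it says the series, first, only, none or still open, it means among the compounds named here.

Compound 1, `CN(Cc1cc(C(F)(F)F)cc(C(F)(F)F)c1)C(=O)c1c(CO)nc2ccccc2c1-c1ccccc1`: 16 nM
Compound 2, `CNCc1nc2ccccc2c(-c2ccccc2)c1C(=O)NCc1cc(C(F)(F)F)cc(C(F)(F)F)c1`: 0.011 nM

In an in vitro assay on UC11MG cells for binding affinity to Substance-P receptor (Homo sapiens), read by radioligand binding (a higher number here means a weaker inhibitor, a lower number a stronger inhibitor), compound 2 gives 0.011 nM, the lowest of the two numbers; compound 1 gives 16 nM, a higher number beyond the scatter. Compound 3, `CC(C)(C)[Si](C)(C)OCc1nc2ccccc2c(-c2ccccc2)c1C(=O)NCc1cc(C(F)(F)F)cc(C(F)(F)F)c1`, differs from compound 2 by a group of 8 heavy atoms (6 carbon, 1 oxygen, 1 silicon; no ring) in place of a group of 2 heavy atoms (1 carbon, 1 nitrogen; no ring), on a saturated chain carbon bound to an aromatic carbon. Within the data shown here, no step between measured compounds isolates this change, so the expectation rests on the two values of compound 2 and compound 1 alone. Compound 3 is expected to bind more weakly than compound 2, with an estimated step of a 270-fold higher number from compound 2 to compound 3 (2.44 log units; beyond the scatter) beyond the scatter. The estimate for compound 3 is 3 nM, expected to lie between 0.1 nM and 100 nM.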

Compound 3, half-maximal inhibitory concentration: 17 nM
Beside the measured number, compound 3's estimate is 5.7-fold (0.75 log units) below it, within the range that was stated.
By their numbers in this assay, from the lowest: compound 2; then compounds 1 and 3 (each within the scatter of the next).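

In this assay, among these compounds, the exchange of methylamino for a group of 8 heavy atoms (6 carbon, 1 oxygen, 1 silicon; no ring), on a saturated chain carbon bound to an aromatic carbon, gives a 1500-fold higher number from compound 2 to compound 3 (3.19 log units; beyond the scatter) and is the first change at this place that can be read alone. The number in this assay therefore depends heavily on what this place carries. Nothing available explains the size of the step.

The compounds shown leave open how a primary amine or a dimethylamino group would stand at this place. They also leave open whether a longer chain ending in an amine would keep the low number of compound 2.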